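Methyl Ester to Carbamoyl: a Solubility Step Forward

The compounds below may be only part of what the source reports. "The series", "measured", "known", "first", "only" and "open" are said of these compounds alone.

Compound 1 `CCOC(=O)c1nc(C)c2c(c1N)C(=O)N(Cc1ccccc1)C2=O` — in a physicochemical assay for solubility, using the shake flask method, in simulated intestinal fluid, measured as kinetic solubility, with a stated time of 2 h, at 25 degrees C, at pH 6.5 (a lower number here means a less soluble compound, a higher number a more soluble compound), compound 1 gives < 5000 nM, which is a limit of the assay and not a number.
Compound 2 `COC(=O)c1nc(C)c2c(c1N)C(=O)N(Cc1ccccc1)C2=O` — in this assay compound 2 gives 7400 nM.

Compound 2 therefore holds the only true number shown, while compound 1 sits at the assay limit (the limit of < 5000 nM in this assay, at which 1 of the 2 values shown sits). Among the compounds with values here, the single measured step, an at least 1.4-fold higher number from compound 1 to compound 2 (0.17 log units; that floor lies within the scatter), is the only comparison available, and its floor does not reach beyond the scatter.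

Compound 3 `Cc1nc(C(N)=O)c(N)c2c1C(=O)N(Cc1ccccc1)C2=O` differs from compound 2 in one place: amino in place of methoxy on a carbonyl carbon. The measured step touched the alkyl part of the ester rather than the ester itself, so it bears on this change only loosely and gives no firm direction. Compound 3 is expected to fall near 10000 nM, within 3500 nM to 30000 nM. That estimate means a step of a 1.4-fold higher number from compound 2 to compound 3 (0.13 log units; within the scatter), which is not expected to stand clearly beyond the scatter.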

Compound 3, solubility: < 5000 nM
Compound 3: a limit, no number; the forecaster's own chance of this, stated with the estimate: 20%; at least 2.0-fold (0.30 log units) between middle value and limit.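

In this assay compound 3 gives < 5000 nM, which is a limit of the assay and not a number. Within the data shown here, the change from methoxycarbonyl to carbamoyl, made on a carbonyl carbon whose other neighbour is an aromatic carbon, gives the first reading at the carbonyl carbon itself, where the earlier step touched only the alkyl part of the ester: an at least 1.4-fold lower number from compound 2 to compound 3 (0.17 log units; that floor lies within the scatter), so it does not stand clearly beyond the scatter. The step between compound 1 and compound 3 cannot be read because both values are limits: the limit of < 5000 nM in this assay, at which 2 of the 3 values shown sit.

From the compounds shown here alone, how far compound 3 lies from that limit remains unknown, which leaves the true size of the change unsettled. Going by these compounds, whether a hydroxyl or a methylamino group on the same carbonyl carbon would give a true number in this assay also remains open.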